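Replacing pentan-3-yl with 1-phenylethyl in a small series

A few compounds are considered here, and "the series" means these few. Any claim that something is new, unique, unknown or untested is made for them only; others in the source may bear on it.

Measured in a functional assay for inhibition, with Rattus norvegicus as the target; on this read-out lower numbers stand for stronger inhibition and higher numbers for weaker inhibition:
Compound 1 `CC(C)(C)/N=c1\c(O)c(O)\c1=N/c1cnc2ccccc2c1`: > 30000 nM (a limit)
Compound 2 `CC(/N=c1\c(O)c(O)\c1=N/c1ccc(S(N)(=O)=O)cc1)C(C)(C)C`: > 30000 nM (a limit)
Compound 3 `CCC(CC)/N=c1\c(O)c(O)\c1=N/c1ccc(C#N)cc1`: 3340 nM

Of the three measured compounds, only compound 3 has a true number, 3340 nM. The other two results are limits, so the set otherwise offers only (the limit of > 30000 nM in this assay, at which 2 of the 3 values shown sit).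

Compound 4 `C[C@H](/N=c1\c(O)c(O)\c1=N/c1ccc(C#N)cc1)c1ccccc1` is not yet measured. It differs from compound 3 in one place, with 1-phenylethyl in place of pentan-3-yl on a double-bonded nitrogen. Within the data shown here, no measured pair isolates a change of this kind, so the size of the step cannot be read from the data. Among the measured compounds shown here, the only numerical anchor is compound 3 at 3340 nM, and the expectation therefore stays close to it, with wide uncertainty on both sides. The estimated step of a 1.1-fold lower number from compound 3 to compound 4 (0.05 log units; within the scatter) lies within the usual scatter, and no direction is expected. For compound 4 the estimated value is 3000 nM, with an expected range of 500 nM to 20000 nM.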

Compound 4, half-maximal inhibitory concentration: > 30000 nM
Compound 4 ended at the assay's limit; the forecaster's own chance of this, stated with the estimate: 20%; at least 10-fold (1.00 log units) between middle value and limit.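

In this assay, among these compounds, replacing pentan-3-yl with 1-phenylethyl on a double-bonded nitrogen gives an at least 8.9-fold higher number from compound 3 to compound 4 (0.95 log units; beyond the scatter), the first step that can be sized at this position. With nothing else changed, this shows that the group on that nitrogen is not interchangeable: here, the entering group with its six-membered aromatic ring of carbon only loses measurable inhibition. The result for compound 4 is a limit, so the step gives only a minimum size: the limit of > 30000 nM in this assay, at which 3 of the 4 values shown sit.

Going by these compounds, whether the loss follows the aromatic ring, the larger group or the defined stereocentre remains open. A cyclohexyl group, a benzyl group or the mirror-image form of 1-phenylethyl on the same nitrogen would separate these possibilities.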